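Replacing dimethoxyphenyl with methoxybenzyl on the shared core

The source may hold more compounds than are shown below. What is called first, only, known or untested is meant among the compounds shown, and "the series" means these compounds.

Measured compounds in a functional assay on FM3A cells (Mus musculus) for inhibition, read by cell counting, with a stated time of 2 days; on this read-out lower numbers stand for stronger inhibition and higher numbers for weaker inhibition:
compound 1, `COc1ccc(-c2nn3cc(-c4cccc(N)c4)nc3s2)cc1OC`: 13000 nM
compound 2, `C=C(Br)C(=O)Nc1cccc(-c2cn3nc(-c4ccc(OC)c(OC)c4)sc3n2)c1`: 110 nM
compound 3, `C=C(Br)C(=O)Nc1cccc(-c2cn3c(-c4ccccc4)csc3n2)c1`: 1300 nM

Compound 2 carries the lowest number of the three in this assay; compound 3 stands above it and compound 1 higher still. Going by the values given here, the only step between compounds differing in one place is a 120-fold lower number from compound 1 to compound 2 (2.07 log units; beyond the scatter), which concerns the acylated nitrogen. Compound 4, `C=C(Br)C(=O)Nc1cccc(-c2cn3nc(Cc4cccc(OC)c4)sc3n2)c1`, differs from compound 2 at another place: 3-methoxybenzyl in place of 3,4-dimethoxyphenyl on an aromatic carbon. Among the compounds with values here, no measured step touches that position, so nothing in the data calibrates this change. A modest loss is expected on balance, a 3.6-fold higher number from compound 2 to compound 4 (0.56 log units; beyond the scatter). Compound 4 is therefore estimated at 400 nM, with a range from 100 nM to 2000 nM.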

Compound 4, half-maximal inhibitory concentration: 1100 nM
Compound 4: middle estimate off by 2.8-fold (0.44 log units), on the low side; the measured number falls inside the stated range.
By their numbers in this assay, from the lowest: compound 2; then compounds 4 and 3 (each within the scatter of the next); then compound 1.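

In this assay, the aromatic carbon of the five-membered ring now has a step of its own: with the acylated nitrogen held constant, 3-methoxybenzyl in place of 3,4-dimethoxyphenyl gives a 10-fold higher number from compound 2 to compound 4 (1.00 log units; beyond the scatter). The group at this position therefore affects the number, and the step lies beyond the scatter. Nothing available explains this step.

The change alters both the phenyl-to-benzyl attachment and the methoxy pattern, and these two contributions cannot be separated here. On these data alone, how an amine, a carboxylic acid or a longer chain would fare at this position remains open.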